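Shortening the Side Chain of Compound 3

The source may report more compounds than this note shows. Statements on the series, on what has been measured and on what is new or still open speak of the compounds shown alone.

Compound 3 `NC(=O)CC[C@H](NC(=O)CN(c1nc(Cl)nc2[nH]cnc12)C1CC1)C(=O)OCc1ccccc1` gives 33.1% in a functional assay on the whole organism (Tail, strain ICR) with Mus musculus as the target, in the tail flick test, with a stated time of 60 min, at a dose of 25 umol/kg by the oral route; a lower number here means a weaker effect, a higher number a stronger effect of the compound at the dose given. Among the three measured compounds it stands second highest; its nearest neighbour is compound 2 `N=C(N)NCCC[C@H](NC(=O)CN(c1nc(Cl)nc2[nH]cnc12)C1CC1)C(=O)OCc1ccccc1`, which gives 30.6%, and the furthest is compound 1 `O=C(CN(c1nc(Cl)nc2[nH]cnc12)C1CC1)NCC(=O)OCc1ccccc1`, which gives 41.9%, both gaps lying within the scatter.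

Compound 4 `NC(=O)C[C@H](NC(=O)CN(c1nc(Cl)nc2[nH]cnc12)C1CC1)C(=O)OCc1ccccc1` differs from compound 3 by carbamoyl in place of carbamoylmethyl on a saturated chain carbon, two bonds along the chain from an amide-type nitrogen and a carbonyl carbon. Within the data shown here, two measured steps bear on this change. The step of a number 8.8 percentage points lower from compound 1 to compound 3 (within the scatter) shows that placing 2-carbamoylethyl on the saturated chain carbon bound to an amide-type nitrogen and a carbonyl carbon moved the read-out only within the scatter, and the step of a number 2.5 percentage points higher from compound 2 to compound 3 (within the scatter) shows that exchanging the group on that chain carbon likewise moved it within the scatter. Among the measured compounds shown here, no measured step shortens the chain itself, so the expectation rests on these two. The step expected in this assay is a number 0.9 percentage points higher from compound 3 to compound 4 (within the scatter), not beyond the scatter. Compound 4 is therefore estimated at 34%, with a range from 20% to 48%.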

Compound 4, a percentage reported as activity, at one dose (the size of the read-out at that dose, not a potency): 36.4%
Compound 4: the middle estimate sits 2.4 percentage points below what was measured; low and high end bracket the measured number.
By their numbers in this assay, from the lowest: compounds 2, 3, 4 and 1 (each within the scatter of the next, the first and the last beyond it).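

In this assay the direct shortening of 2-carbamoylethyl to carbamoylmethyl gives a number 3.3 percentage points higher from compound 3 to compound 4 (within the scatter) and so leaves the read-out indistinguishable from that of the longer chain. The steps of a number 5.8 percentage points higher from compound 2 to compound 4 (within the scatter) and a number 5.5 percentage points lower from compound 1 to compound 4 (within the scatter) also stay within the scatter, so compound 4 cannot be separated from compound 2 or compound 1, even though those two lie beyond the scatter of each other. No supporting evidence is available to explain why this change has so little effect on the read-out.

As far as these compounds go, whether a carboxylic acid or an amine in place of the carbamoyl group, or a longer chain than 2-carbamoylethyl, would move the read-out beyond the scatter remains open. The compounds shown also leave open whether this insensitivity to chain length would hold with a different ester in place of the benzyl ester.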